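The source may hold more compounds than are shown below. What is called first, only, known or untested is meant among the compounds shown, and "the series" means these compounds.

Measured so far:
compound 1, `O=C(Nc1ccccc1O)c1cccc(N2C(=O)c3ccccc3C2=O)c1`: 77 nM
compound 2, `O=C(Nc1cccc(NC(=O)c2ccc(Cl)c(Cl)c2)c1)c1cccc(Cl)c1`: > 30000 nM

In an in vitro functional assay on HEK293-A cells for antagonist activity at metabotropic glutamate receptor 5 (Rattus norvegicus), read by calcium flux (on this read-out lower numbers stand for stronger inhibition and higher numbers for weaker inhibition), compound 1 gives 77 nM. Compound 2 sits at the limit of > 30000 nM in this assay, at which 1 of the 2 values shown sits, a limit of the assay and not a number. Among the compounds with values here, compound 1 therefore stands as the only compound with a numerical value here; the other value shown is a limit, so nothing can be said about the size of the gap between them.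

Compound 3, `O=C(Nc1ccccc1F)c1cccc(N2C(=O)c3ccccc3C2=O)c1`, has not yet been measured in this assay. It differs from compound 1 in one place: fluoro in place of hydroxy on an aromatic carbon. Within the data shown here, no pair of measured compounds differs in just one place, so there is no measured step of this kind to lean on, and the expectation rests on compound 1 alone. The change is expected to weaken inhibition slightly, beyond the usual scatter but not by much, giving an estimated step of a 2.6-fold higher number from compound 1 to compound 3 (0.41 log units; beyond the scatter). For compound 3 the expected value in this assay is 200 nM, with a likely range from 40 nM to 1500 nM.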

Compound 3, half-maximal inhibitory concentration: 1050 nM
Compound 3: middle estimate off by 5.3-fold (0.72 log units), on the low side; measured number inside the range.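

Replacing hydroxy with fluoro on this aromatic carbon, ortho to a large group, gives a 14-fold higher number from compound 1 to compound 3 (1.13 log units; beyond the scatter) in this assay, which shows that the result at this position depends strongly on the group placed there, although compound 3 still gives a numerical value of 1050 nM. By the computed count, hydroxy brings a hydrogen-bond donor and a hydrogen-bond acceptor while fluoro brings neither, but this single step cannot separate that difference from any other difference between the two groups. No measurement shown here bears on why this change produces so large a step.

From the compounds shown here alone, the comparison at this position rests on one pair of compounds, so it remains open how an amine, a methoxy group or a plain hydrogen on the same carbon would read out. Going by these compounds, it is also open whether the same swap would produce a step of similar size at another place on this ring or on a different core.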